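Dinitrophenyl for dialkylphenyl on the triazole of the spiro core

A few compounds are considered here, and "the series" means these few. Any claim that something is new, unique, unknown or untested is made for them only; others in the source may bear on it.

Measured compounds:
compound 1 `Cc1ccccc1-n1nncc1CN1C(=O)C2(C(C#N)=C(N)Oc3c(N)cc4nc5ccccc5nc4c32)c2ccccc21` — a limit of > 50000 nM in a functional assay on HCT-116 cells (Homo sapiens) for antiproliferative activity, read by MTT assay, with a stated time of 48 h; a lower number here means a stronger inhibitor, a higher number a weaker inhibitor
compound 2 `CCc1cccc(C)c1-n1nncc1CN1C(=O)C2(C(C#N)=C(N)Oc3c(N)cc4nc5ccccc5nc4c32)c2ccccc21` — a limit of > 50000 nM in this assay

Compound 1 gives only an assay limit in this assay. Compound 2 likewise gives only a limit in this assay. The step that the two limits leave unreadable from compound 1 to compound 2 is therefore unreadable, and both values sit at the limit of > 50000 nM in this assay, at which 2 of the 2 values shown sit. Compound 3 `N#CC1=C(N)Oc2c(N)cc3nc4ccccc4nc3c2C12C(=O)N(Cc1cnnn1-c1ccc([N+](=O)[O-])cc1[N+](=O)[O-])c1ccccc12` differs from compound 2 by 2,4-dinitrophenyl in place of 2-ethyl-6-methylphenyl on an aromatic nitrogen. Going by the values given here, no measured step bears on this change, and compound 2 stands only at a limit, so no direction beyond the scatter is expected in this assay. Compound 3 is estimated at 50000 nM, within 20000 nM to 100000 nM, an expected step of a number no higher from compound 2 to compound 3 (the limit leaves the size open), most likely again reported as a limit.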

Compound 3, half-maximal inhibitory concentration: 23900 nM
Compound 3: middle estimate off by 2.1-fold (0.32 log units), on the high side; the measured number falls inside the stated range.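

In this assay, going by these compounds alone, compound 3 gives 23900 nM, the first value that is not a limit, which shows that the group on this aromatic nitrogen can shift the read-out. From the compounds shown here alone, the change to 2,4-dinitrophenyl brings an at least 2.0-fold lower number from compound 2 to compound 3 (0.32 log units; beyond the scatter) and an at least 2.0-fold lower number from compound 1 to compound 3 (0.32 log units; beyond the scatter), and the true sizes of both steps stay open. Compound 1 and compound 2 remain at an assay limit: the limit of > 50000 nM in this assay, at which 2 of the 3 values shown sit.

Open, going by these compounds, is whether a single nitro group on the phenyl ring would give a step of this kind. Also open, on these data alone, is how an amine or a carboxylic acid on that ring would read.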